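Methoxy for chloro on the fused core: working notes

A few compounds are considered here, and "the series" means these few. Any claim that something is new, unique, unknown or untested is made for them only; others in the source may bear on it.

Measured compounds, with their read-outs in an assay on isolated protein (Cricetulus griseus) for binding affinity to Alpha-1B adrenergic receptor (Mesocricetus auratus), read by radioligand binding; on this read-out lower numbers stand for stronger inhibition and higher numbers for weaker inhibition:
compound 1 `CS(=O)(=O)Nc1ccc(Cl)c2c1CCCC2c1c[nH]cn1` gives < 10000 nM, which is a limit of this assay.
compound 2 `CCCS(=O)(=O)Nc1cccc2c1CCCC2c1c[nH]cn1` gives < 10000 nM, which is a limit of this assay.
compound 3 `CCS(=O)(=O)Nc1cccc(Sc2c[nH]cn2)c1` gives < 10000 nM, which is a limit of this assay.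

Compound 1 stands only at a limit; no number fixes its place. Among the measured compounds shown here, all measured values sit at the limit of < 10000 nM in this assay, at which 3 of the 3 values shown sit, so no step between measured compounds can be sized or ordered. Compound 4 `COc1ccc(NS(C)(=O)=O)c2c1C(c1c[nH]cn1)CCC2` differs from compound 1 in one place: methoxy in place of chloro on an aromatic carbon. For the measured compounds named here, with every measured value a limit, the data give no size for this step in this assay; the expectation is a change no larger than the usual scatter, in neither direction. For compound 4 the estimate is 1500 nM, with the range 150 nM to 10000 nM. The expected step is a step that the limit leaves unreadable from compound 1 to compound 4, within scatter.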

Compound 4, inhibition constant: < 10000 nM
Compound 4 gave a limit, no number; the forecaster's own chance of this, stated with the estimate: 70%; the middle value lies beyond the limit too.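

No step can be read between compound 1 and compound 4, since both stand only at a limit: the limit of < 10000 nM in this assay, at which 4 of the 4 values shown sit.

The compounds shown leave open whether methoxy and chloro differ at all on the shared core.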